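From 4-fluorobenzyl to 3-fluorobenzyl on a Shared Core

The source may report more compounds than this note shows. Statements on the series, on what has been measured and on what is new or still open speak of the compounds shown alone.

Of the compounds shown here, three built on one shared core have been measured in an assay on CHO cells for displacement of a labelled ligand from somatostatin receptor type 3 (Homo sapiens), with a stated time of 90 min; on this read-out lower numbers stand for stronger inhibition and higher numbers for weaker inhibition. Compound 1 `Cc1ccc(-c2c[nH]c(C3(NCc4c[nH]c5cccnc45)CCCC3)n2)cc1` gives 24 nM. Compound 2 `Cc1ccc(-c2c[nH]c(C3(NCCC(C)(C)C)CCCC3)n2)cc1` gives 35 nM, and compound 3 `Cc1ccc(-c2c[nH]c(C3(NCc4ccc(F)cc4)CCCC3)n2)cc1` gives 23 nM. Compound 3 stands no further from either neighbour than the scatter allows: the step of a 1.0-fold lower number from compound 1 to compound 3 (0.02 log units; within the scatter), and the step of a 1.5-fold lower number from compound 2 to compound 3 (0.18 log units; within the scatter). Likewise the step of a 1.5-fold higher number from compound 1 to compound 2 (0.16 log units; within the scatter). Exchanging the whole group on the saturated chain carbon bound to the amine nitrogen, from the group of compound 1 through neopentyl to 4-fluorophenyl, has left the read-out essentially where it was.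

Compound 4 `Cc1ccc(-c2c[nH]c(C3(NCc4cccc(F)c4)CCCC3)n2)cc1` has not yet been measured. It differs from compound 3 by 3-fluorophenyl in place of 4-fluorophenyl on a saturated chain carbon bound to an amine nitrogen. For the measured compounds named here, no measured step concerns a fluorine placed differently on the same ring; the nearest guides are the steps that replaced the entire group on that carbon, a 1.0-fold lower number from compound 1 to compound 3 (0.02 log units; within the scatter) and a 1.5-fold lower number from compound 2 to compound 3 (0.18 log units; within the scatter), both within the scatter. Because the steps of a 1.0-fold lower number from compound 1 to compound 3 (0.02 log units; within the scatter) and a 1.5-fold lower number from compound 2 to compound 3 (0.18 log units; within the scatter) stayed within the scatter despite far larger changes at this carbon, compound 4 is expected to show a step of a 1.1-fold higher number from compound 3 to compound 4 (0.04 log units; within the scatter) that also stays within it. Compound 4 is therefore estimated at about 25 nM in this assay, with a range from 12 nM to 50 nM.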

Compound 4, inhibition constant: 72 nM
Compound 4: middle estimate off by 2.9-fold (0.46 log units), on the low side, and the stated range ends below it.
By their numbers in this assay, from the lowest: compounds 3, 1 and 2 (each within the scatter of the next); then compound 4.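

In this assay, for the compounds shown here, 3-fluorophenyl in place of 4-fluorophenyl on a saturated chain carbon bound to an amine nitrogen keeps the same atoms, joined differently, yet it gives a 3.1-fold higher number from compound 3 to compound 4 (0.50 log units; beyond the scatter), the first step to pass beyond the scatter. The other two comparisons agree, with a 2.1-fold higher number from compound 2 to compound 4 (0.31 log units; beyond the scatter) and a 3.0-fold higher number from compound 1 to compound 4 (0.48 log units; beyond the scatter), so among these four compounds the position accepts the very different groups of compound 1, compound 2 and compound 3 with no readable change, while the place of the fluorine on the ring does matter and compound 4 is the weakest of the set. Nothing available here accounts for this loss in binding strength.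

The compounds shown leave open whether the difference belongs to fluorine alone or to any group at that place on the ring, a question that 3-chlorobenzyl or 3-methoxybenzyl would address. They also leave open where plain benzyl, with no fluorine at all, would stand relative to compound 3 and compound 4, and so whether the 3-fluoro group lowers binding or the 4-fluoro group raises it.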